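A few compounds are considered here, and "the series" means these few. Any claim that something is new, unique, unknown or untested is made for them only; others in the source may bear on it.

Measured so far in an assay on isolated protein for inhibition of Indoleamine 2,3-dioxygenase 1 (Homo sapiens), with a stated time of 60 min, tested at 10 uM; a higher number here means more inhibition at the concentration tested (going by the name of the read-out), a lower number less inhibition:
compound 1 `Clc1ccc2[nH]c(SCc3ccccc3CCc3ccccc3)nc2c1`: 47%
compound 2 `[O-][S+](Cc1ccccc1)c1ccccc1CSc1nc2cc(Cl)ccc2[nH]1`: 11%

Among the compounds with values here, compound 2 stands at the lowest of the two numbers; its only neighbour is compound 1, and the single measured step between them is a number 36 percentage points lower from compound 1 to compound 2 (beyond the scatter), a large loss on going to the group of 9 heavy atoms.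

Compound 3 `Clc1ccc2[nH]c(SCc3ccccc3/C=C/c3ccccc3)nc2c1` differs from compound 2 by a group of 8 heavy atoms (8 carbon; one six-membered aromatic ring of carbon only) in place of a group of 9 heavy atoms (7 carbon, 1 oxygen, 1 sulfur; one six-membered aromatic ring of carbon only), on an aromatic carbon. The group that enters, 2-phenylethenyl, shares with the group carried by compound 1 at the same place its count of 8 heavy atoms, all carbon, and its one six-membered aromatic ring of carbon only; it adds only one double bond outside aromatic rings. Within the data shown here, the one step that bears on this change is a number 36 percentage points lower from compound 1 to compound 2 (beyond the scatter), which runs in the opposite direction: there the group of 8 carbon atoms was exchanged for the group of 9 heavy atoms and inhibition fell well beyond the scatter. Reversing that exchange is therefore expected to bring the number back up by a step of comparable size, a number 34 percentage points higher from compound 2 to compound 3 (beyond the scatter). Compound 3 is estimated at 45%, with a range from 25% to 65%.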

Compound 3, a percentage reported as inhibition, at one concentration (the size of the read-out at that concentration, not a potency): -6%
Compound 3: the middle estimate sits 51 percentage points above what was measured; the measured number lies below the stated range.
By their numbers in this assay, from the lowest: compound 3; then compound 2; then compound 1.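

In this assay, the place on an aromatic carbon, ortho to a large group, proves sensitive to more than the heavy-atom count and the ring: with 2-phenylethenyl in place of phenethyl, the change gives a number 53 percentage points lower from compound 1 to compound 3 (beyond the scatter) even though the entering group differs from phenethyl only by one double bond outside aromatic rings. Compound 2 therefore no longer marks the low end at this place, and the exchange of its group for 2-phenylethenyl gives a number 17 percentage points lower from compound 2 to compound 3 (beyond the scatter) rather than any recovery towards compound 1. Among the three compounds, phenethyl alone gives a clearly higher number, so similarity in composition to phenethyl does not by itself carry inhibition here, and no measurement in hand accounts for the loss.

Open, from the compounds shown here alone, is how far the saturated link can be changed at this place, for instance whether a three-carbon phenylpropyl chain or an amine within the link retains the number of compound 1. Also open, going by these compounds, is whether a carboxylic acid or a methoxy group on the terminal phenyl ring of phenethyl moves the number in either direction, since all three compounds carry that ring unsubstituted.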